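Aryl variation at the branching carbon of a diaryl acetamide

The compounds below may be only part of what the source reports. "The series", "measured", "known", "first", "only" and "open" are said of these compounds alone.

Three compounds sharing one core were measured in an assay on CHO cells for antagonist activity at transient receptor potential cation channel subfamily V member 1 (Homo sapiens), read by FLIPR; on this read-out higher numbers stand for weaker inhibition and lower numbers for stronger inhibition. Compound 1 `CC1CCN(c2nc(C(F)(F)F)ccc2CNC(=O)C(c2ccc(NS(C)(=O)=O)c(F)c2)C2CCCC2)CC1` gives 88.7 nM in this assay. Compound 2 `CC1CCN(c2nc(C(F)(F)F)ccc2CNC(=O)C(c2ccccc2)c2ccc(NS(C)(=O)=O)c(F)c2)CC1` gives 1.3 nM in this assay, and compound 3 `CC1CCN(c2nc(C(F)(F)F)ccc2CNC(=O)C(c2ccc(F)cc2)c2ccc(NS(C)(=O)=O)c(F)c2)CC1` gives 3.4 nM in this assay. Among the three numbers, compound 3 stands second highest: the change was a 2.6-fold higher number from compound 2 to compound 3 (0.42 log units; beyond the scatter), while a 26-fold lower number from compound 1 to compound 3 (1.42 log units; beyond the scatter) and a 68-fold lower number from compound 1 to compound 2 (1.83 log units; beyond the scatter) show that replacing the cyclopentyl with either aromatic ring brought a large drop in the number.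

Compound 4 `Cc1ccccc1C(C(=O)NCc1ccc(C(F)(F)F)nc1N1CCC(C)CC1)c1ccc(NS(C)(=O)=O)c(F)c1` differs from compound 3 by 2-methylphenyl in place of 4-fluorophenyl on a saturated chain carbon bound to an aromatic carbon and a carbonyl carbon. For the measured compounds named here, no measured step swaps one substituted phenyl for another at this carbon. What bears on the change is that both phenyl and 4-fluorophenyl gave low numbers relative to compound 1, and that the fluoro on the ring moved the number only modestly between compound 2 and compound 3. The account therefore expects compound 4 to keep a low number in this assay, with a step no larger than modest in either direction, a 1.0-fold higher number from compound 3 to compound 4 (0.01 log units; within the scatter). For compound 4 the estimated value is 3.5 nM, within a range from 1 nM to 12 nM.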

Compound 4, inhibition constant: 42.9 nM
Compound 4: the middle estimate sits 12-fold (1.09 log units) below what was measured; the measured number lies above the stated range.
By their numbers in this assay, from the lowest: compound 2; then compound 3; then compound 4; then compound 1.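

At this saturated chain carbon, an aromatic ring alone does not secure a low number in this assay: a methyl group added to the phenyl ring gave a 33-fold higher number from compound 2 to compound 4 (1.52 log units; beyond the scatter), far more than a 2.6-fold higher number from compound 2 to compound 3 (0.42 log units; beyond the scatter) that came with fluoro, and the exchange of 4-fluorophenyl for 2-methylphenyl gave a 13-fold higher number from compound 3 to compound 4 (1.10 log units; beyond the scatter). The position therefore distinguishes between substituted phenyl rings, which the two earlier aromatic compounds did not reveal, and with 2-methylphenyl in place of cyclopentyl only a modest part of the earlier drop remains, a 2.1-fold lower number from compound 1 to compound 4 (0.32 log units; beyond the scatter). Nothing available here accounts for the sharp rise in the number with 2-methylphenyl.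

The compounds shown do not separate the methyl group itself from where it sits on the ring, since fluoro and methyl occupy different places in 4-fluorophenyl and 2-methylphenyl. On these data alone, how a chloro or a methoxy group on the phenyl ring would behave at this carbon also remains open.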